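This account rests on a few compounds, and the source may have more. Where it says the series, first, only, none or still open, it means among the compounds named here.

Measured compounds in an assay on isolated protein for inhibition of myosin-2 (Bos taurus), read by spectrophotometry, with a stated time of 24 min; a lower number here means a stronger inhibitor, a higher number a weaker inhibitor:
- compound 1, `C/C(=N\CC1CCCCC1)c1c(O)c2ccccc2[nH]c1=O`: >= 100000 nM
- compound 2, `CC/C(=N\Cc1ccccc1)c1c(O)c2ccccc2oc1=O`: >= 100000 nM
- compound 3, `C/C(=N\CCCO)c1c(O)c2ccccc2oc1=O`: 37000 nM

Compound 2 gives only a limit in this assay, >= 100000 nM, so no number is available for it. The same holds for compound 1, whose reading is likewise a limit, >= 100000 nM. For the measured compounds named here, compound 3 is the one member of the series with a measured number, 37000 nM. Compound 2 therefore stands at the weak end of what this assay can report, alongside compound 1, as summarised by the limit of >= 100000 nM in this assay, at which 2 of the 3 values shown sit.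

The next compound, compound 4, `CCC/C(=N\Cc1ccccc1)c1c(O)c2ccccc2oc1=O`, has not been measured in this assay. It differs from compound 2 in one place: methyl in place of hydrogen on a saturated chain carbon, two bonds along the chain from a carbon with a double bond to nitrogen. Going by the values given here, no pair of measured compounds differs in a single place, so no measured step is available to calibrate the change.

Given that compound 2 already sits at the limit, >= 100000 nM, the addition of a methyl on the saturated chain is expected to give no step beyond the scatter, a number no higher from compound 2 to compound 4 (the limit leaves the size open), with the most likely outcome being another limit. Compound 4 is accordingly estimated at 100000 nM, with a range from 40000 nM to 300000 nM.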

Compound 4, half-maximal inhibitory concentration: >= 100000 nM
Compound 4: no number, only a limit; the forecaster's own chance of this, stated with the estimate: 80%; the middle value sits exactly at the limit.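

Compound 2 and compound 4 each give only a limit in this assay, so no step can be read between them: the limit of >= 100000 nM in this assay, at which 3 of the 4 values shown sit.

The compounds shown leave open whether methyl in place of hydrogen on this saturated chain carbon changes inhibition at all, and if so, in which direction and by how much.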